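The compounds below may be only part of what the source reports. "The series", "measured", "known", "first", "only" and "open" are said of these compounds alone.

Compound 1, `COc1ncc(-c2ccc3nc(NC(=O)N4CCCC4)nn3c2)cc1NS(=O)(=O)c1ccc(F)cc1`, was tested in a functional assay on U-87MG ATCC cells for cytotoxicity against U-87 MG (Homo sapiens), read by MTT assay, with a stated time of 72 h (a lower number here means a stronger inhibitor, a higher number a weaker inhibitor), where compound 1 gives 1690 nM. Among the compounds with values here, only one other compound has a number here: compound 2, `CCN(CC)CCNC(=O)Nc1nc2ccc(-c3cnc(OC)c(NS(=O)(=O)c4ccc(F)cc4F)c3)cn2n1`, which in this assay gives 1060 nM. These two values sit within the usual scatter of each other, so neither can be said to stand apart from the other, and compound 1 is simply one of two measured points.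

Compound 3, `CNC(=O)Nc1nc2ccc(-c3cnc(OC)c(NS(=O)(=O)c4ccc(F)cc4)c3)cn2n1`, has not been measured yet. It is built from compound 1 by one change: methylamino in place of pyrrolidin-1-yl on a carbonyl carbon. Within the data shown here, no pair of measured compounds differs by this change alone, so nothing shows directly what it does. Compound 2 carries a different group at the same urea end and gives 1060 nM, not far from compound 1, which suggests this end tolerates variation. The step of a 1.1-fold lower number from compound 1 to compound 3 (0.05 log units; within the scatter) is therefore expected to stay within the scatter, in no clear direction. Compound 3 is estimated at 1500 nM, with a range from 500 nM to 4500 nM.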

Compound 3, half-maximal inhibitory concentration: 640 nM
Beside the measured number, compound 3's estimate is 2.3-fold (0.37 log units) above it, within the range that was stated.
By their numbers in this assay, from the lowest: compounds 3, 2 and 1 (each within the scatter of the next, the first and the last beyond it).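

In this assay the group on this carbonyl carbon does matter: methylamino in place of pyrrolidin-1-yl gives a 2.6-fold lower number from compound 1 to compound 3 (0.42 log units; beyond the scatter) and this modest step lies beyond the usual scatter. Within the data shown here, this is the first one-place comparison at this position, and it shows that the smaller group without a ring, which also brings a hydrogen-bond donor, goes with the lower number. No measurement shown here accounts for the step.

Among these compounds, the single step cannot separate the loss of the ring from the gain of the donor, since both happen together. Dimethylamino on the same carbonyl carbon would bear on that question, and ethylamino or a longer chain would show how far the trend runs beyond methylamino.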